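This account rests on a few compounds, and the source may have more. Where it says the series, first, only, none or still open, it means among the compounds named here.

Compound 1 `CC(C)CCn1ccc(-c2ccccc2)c(C#N)c1=O` gives 8510 nM in a functional assay on CHO cells for positive allosteric modulation of metabotropic glutamate receptor 2 (Homo sapiens), read by scintillation counting and GTPgammaS binding, with a stated time of 30 min; a higher number here means that more compound is needed for the effect, a lower number that less compound is needed. Compound 2 `COc1ccccc1-c1ccn(CCC(C)C)c(=O)c1C#N` reaches only the limit of this assay, > 10000 nM. Compound 3 `COc1ccc(-c2ccn(CCC(C)C)c(=O)c2C#N)cc1F` gives 1170 nM.

Among the numbers shown, compound 3 stands lowest; compound 1 sits higher by a margin beyond the scatter, and compound 2 shows a limit (the limit of > 10000 nM in this assay, at which 1 of the 3 values shown sits). Compound 4 `COc1ccc(-c2ccn(CCC(C)C)c(=O)c2C#N)cc1OC` carries methoxy in place of fluoro on an aromatic carbon. Among the compounds with values here, the one measured step touching a methoxy entering an aromatic carbon is an at least 1.1-fold higher number from compound 1 to compound 2 (0.07 log units; that floor lies within the scatter), which ends at a limit, so its true size is open. Within the data shown here, no measured step removes a fluoro. The change is therefore expected to move the number only modestly. Compound 4 is estimated at 1800 nM in this assay, with a range from 600 nM to 6000 nM. That means an expected 1.5-fold higher number from compound 3 to compound 4 (0.19 log units; within the scatter).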

Compound 4, half-maximal effective concentration: 260 nM
The estimate for compound 4 lay 6.9-fold (0.84 log units) above the measured number; the measured number lies below the stated range.
By their numbers in this assay, from the lowest: compound 4; then compound 3; then compound 1. At a limit, above all of these: compound 2.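

At this position, on an aromatic carbon ortho to a methoxy group and meta to a large group, methoxy in place of fluoro gives a 4.5-fold lower number from compound 3 to compound 4 (0.65 log units; beyond the scatter) in this assay. This is the first step shown in which a methoxy group entering an aromatic carbon can be read as going with a lower number. The earlier methoxy step gave no such reading, as compound 2 stands at a limit: the limit of > 10000 nM in this assay, at which 1 of the 4 values shown sits.

As far as these compounds go, what a hydroxyl, an ethoxy group or an amine would give at this position stays open. Also open, from the compounds shown here alone, is whether the same change holds with a longer chain in place of the shared one.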